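Anilinothiazole Series: Predicting a Halogen and Methyl Exchange

This account rests on a few compounds, and the source may have more. Where it says the series, first, only, none or still open, it means among the compounds named here.

Measured compounds: compound 1 `CCN(CC)C(=O)c1sc(Nc2c(Cl)cc(Cl)cc2Cl)nc1C`, 5000 nM; compound 2 `CCCN(Cc1sc(Nc2c(C)cc(Cl)cc2Cl)nc1C(F)(F)F)CC1CC1`, 16 nM.

In an assay for displacement of a labelled ligand from corticotropin-releasing factor receptor 1 (Homo sapiens) (a lower number here means a stronger inhibitor, a higher number a weaker inhibitor), compound 1 gives 5000 nM. In this assay compound 2 gives 16 nM, the lowest of the two numbers shown, and its gap to compound 1 lies well beyond the usual scatter, so compound 2 is the stronger inhibitor of the pair. Among the measured compounds shown here, no single-point step between the two measured compounds is available; they differ in several places at once.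

Compound 3 `CCCN(Cc1sc(Nc2c(C)cc(C)cc2Br)nc1C(F)(F)F)CC1CC1` keeps the core of compound 2 and changes only the aryl group on the anilino nitrogen: 2-bromo-4,6-dimethylphenyl in place of 2,4-dichloro-6-methylphenyl on a nitrogen on an aromatic ring. Given that both groups carry the same count of heavy atoms and no donors or acceptors, the step from compound 2 is expected to be small, with no change beyond the scatter, in either direction. The estimated step of a 1.3-fold higher number from compound 2 to compound 3 (0.10 log units; within the scatter) reflects that expectation. Compound 3 is estimated at 20 nM, within a range from 6 nM to 70 nM.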

Compound 3, inhibition constant: 21 nM
Compound 3: the middle estimate sits 1.1-fold (0.02 log units) below what was measured, within the range that was stated.
By their numbers in this assay, from the lowest: compounds 2 and 3 (each within the scatter of the next); then compound 1.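

Among the compounds shown here, the first comparison that differs in only one place comes from this assay: placing 2-bromo-4,6-dimethylphenyl in place of 2,4-dichloro-6-methylphenyl on a nitrogen on an aromatic ring gives (a 1.3-fold higher number from compound 2 to compound 3 (0.12 log units; within the scatter)). With the rest of the molecule held constant, this aryl group can therefore take bromine and an added methyl in exchange for chlorine without a change that can be told apart from the scatter. No measurement shown explains why the two aryl groups read alike.

Going by these compounds, the exchange alters two things on the ring at once, so the separate contribution of each remains open, and a 2,4,6-trimethylphenyl group would be needed to address this. On these data alone, how a methoxy group or a carboxylic acid on that ring would read in this assay also remains open.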